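The source may report more compounds than this note shows. Statements on the series, on what has been measured and on what is new or still open speak of the compounds shown alone.

Measured in an ADME assay on 2209-23 cells (Homo sapiens) for cytotoxicity, read by WST assay and thymidine incorporation (a lower number here means that less compound is tolerated, a higher number that more compound is tolerated), each value being a limit of the assay and not a number:

Compound 1 `CC(C)(C)CCN1C(=O)C(C2=CS(=O)(=O)c3cc(NS(C)(=O)=O)ccc3N2)=C(O)[C@@H]1C(C)(C)C`: > 50000 nM
Compound 2 `CC(C)(C)[C@H]1C(O)=C(C2=C(Cl)S(=O)(=O)c3cc(NS(C)(=O)=O)ccc3N2)C(=O)N1Cc1ccc(F)cc1`: > 50000 nM
Compound 3 `CC(C)(C)[C@H]1C(O)=C(C2=CS(=O)(=O)c3cc([N+](=O)[O-])ccc3N2)C(=O)N1Cc1ccc(F)cc1`: > 50000 nM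

Compound 1 has no exact number in this assay, since its > 50000 nM is a limit. The other two compounds share that position, as the set shows (the limit of > 50000 nM in this assay, at which 3 of the 3 values shown sit).

Compound 4 `CC(C)(C)[C@H]1C(O)=C(C2=CS(=O)(=O)c3cc(NS(C)(=O)=O)ccc3N2)C(=O)N1Cc1ccc(F)cn1` has not yet been measured. It differs from compound 1 in one place, with 5-fluoropyridin-2-yl in place of neopentyl on a saturated chain carbon bound to an amide-type nitrogen in a ring. Among the compounds with values here, no measured pair shows what such a change does in this assay.

No shift beyond the scatter is expected, in either direction, and the estimated size is a number no higher from compound 1 to compound 4 (the limit leaves the size open). This expectation rests on compound 1, whose limit is > 50000 nM. The assay may well report only a limit again. For compound 4 the expected half-maximal cytotoxic concentration is 50000 nM, with an estimated range from 20000 nM to 100000 nM.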

Compound 4, half-maximal cytotoxic concentration: > 50000 nM
Compound 4: no number, only a limit (the forecaster's own chance of this, stated with the estimate: 80%); the middle value lies on the limit itself.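

Compound 1 and compound 4 both sit at a limit in this assay, so no step between them can be read: the limit of > 50000 nM in this assay, at which 4 of the 4 values shown sit.

The compounds shown leave open what concentration any of them would need to reach half-maximal cytotoxicity, and so whether 5-fluoropyridin-2-yl in place of neopentyl changes anything in this assay.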